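The source may report more compounds than this note shows. Statements on the series, on what has been measured and on what is new or still open speak of the compounds shown alone.

Among the measured compounds shown here, compound 2 `Cc1cc(C)c(NC(=O)N(Cc2ccc(-c3ccn(C)n3)cc2)C2CCCCCC2)c(C)c1` is one of two compounds measured in an assay on microsomes from intestine for inhibition of acyl-CoA:cholesterol acyltransferase (Oryctolagus cuniculus); on this read-out higher numbers stand for weaker inhibition and lower numbers for stronger inhibition; in this assay compound 2 gives 44 nM. Its companion, compound 1 `Cc1cc(C)c(NC(=O)N(Cc2ccc(-c3cc[nH]n3)cc2)C2CCCCCC2)c(C)c1`, carries the same core with a hydrogen instead of a methyl on the aromatic nitrogen of the pyrazole; in this assay compound 1 gives 52 nM. For the measured compounds named here, the only step among the measured pair, a 1.2-fold lower number from compound 1 to compound 2 (0.07 log units; within the scatter), is too small to set the two apart, so compound 2 cannot be called the more potent of the two.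

Compound 3 `Cc1cc(C)c(NC(=O)N(Cc2ccc(-c3cnn(C)c3)cc2)C2CCCCCC2)c(C)c1` is not yet measured. It differs from compound 2 in a single place: 1-methyl-1H-pyrazol-4-yl in place of 1-methyl-1H-pyrazol-3-yl on an aromatic carbon. Neither measured step touches this kind of change, which moves the point of attachment of the pyrazole rather than adding or removing atoms. Going by the values given here, the one step seen so far, a 1.2-fold lower number from compound 1 to compound 2 (0.07 log units; within the scatter), shows that a small edit on this pyrazole left the number within the scatter, but it gives no direct guide to the shift of the ring's attachment. Among the compounds with values here, with no bearing step, the expected change from compound 2 to compound 3 in this assay is a 1.1-fold higher number from compound 2 to compound 3 (0.06 log units; within the scatter), that is, none beyond the scatter. Compound 3 is therefore estimated at 50 nM, with a range from 20 nM to 130 nM.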

Compound 3, half-maximal inhibitory concentration: 47 nM
The estimate for compound 3 lay 1.1-fold (0.03 log units) above the measured number; the measured number falls inside the stated range.
By their numbers in this assay, from the lowest: compounds 2, 3 and 1 (each within the scatter of the next).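

In this assay, 1-methyl-1H-pyrazol-4-yl in place of 1-methyl-1H-pyrazol-3-yl on the aromatic carbon para to a large group gives a 1.1-fold higher number from compound 2 to compound 3 (0.03 log units; within the scatter), which shows that this position accepts a shift in the attachment of the pyrazole with no change beyond the scatter, something the earlier pair could not show. The wider edit, 1-methyl-1H-pyrazol-4-yl in place of 1H-pyrazol-3-yl, gives a 1.1-fold lower number from compound 1 to compound 3 (0.04 log units; within the scatter), so changing the point of attachment and the methyl on the aromatic nitrogen together also leaves the three compounds indistinguishable on this read-out. Nothing at hand explains why the number holds steady when the ring is attached differently.

Going by these compounds, all three compounds carry a pyrazole with only a hydrogen or a methyl on the aromatic nitrogen, so it remains open whether an ethyl, a longer chain, or a chain ending in an amine or a carboxylic acid would be accepted there as well. On these data alone, it is equally open whether a pyridine or a phenyl in place of the pyrazole at this position would keep the number where it stands.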